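Straightening an Ether Side Chain: Compound 2 to Compound 4

The source may hold more compounds than are shown below. What is called first, only, known or untested is meant among the compounds shown, and "the series" means these compounds.

Of the compounds shown here, three from this series have been measured in a functional assay on P388 cells (Mus musculus) for cytotoxicity; a lower number here means that less compound is needed, a higher number that more compound is needed for the effect. Compound 1 `Oc1ccc2nc(-c3ccccc3)cc(O)c2c1` gives 2.86 ug/mL. Compound 3 `Oc1cc(-c2ccccc2)nc2cc(F)ccc12` gives 0.29 ug/mL. Compound 2 `CC(C)COc1cc(-c2ccccc2)nc2ccccc12` gives only a limit of the assay, > 10 ug/mL, so no number is known for it. Among the three values shown, compound 2 sits at the limit of > 10 ug/mL in this assay, at which 1 of the 3 values shown sits, while compounds 1 and 3 have measured numbers, so compound 2 stands apart from both of them, needing more material than the assay could resolve.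

Compound 4 `CCCCOc1cc(-c2ccccc2)nc2ccccc12` has not yet been measured. It differs from compound 2 in one place: propyl in place of isopropyl on a saturated chain carbon bound to an oxygen on an aromatic ring. The two have the same atoms, joined differently. No step between measured compounds is known, so nothing shown tells how such a change acts in this assay.

He expects the step that the limit leaves unreadable from compound 2 to compound 4 to be none beyond the scatter, with no clear direction. He estimates compound 4 at 15 ug/mL, in a range from 4 ug/mL to 60 ug/mL, and expects a fair chance that this assay again reports only a limit for compound 4.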

Compound 4, half-maximal effective concentration: > 10 ug/mL
Compound 4 ended at the assay's limit; the forecaster's own chance of this, stated with the estimate: 65%; the middle value lies beyond the limit too.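

Compound 2 and compound 4 both end at a limit of the assay rather than a number, so no step between them can be read in this assay: the limit of > 10 ug/mL in this assay, at which 2 of the 4 values shown sit.

The compounds shown leave open whether isobutoxy and butoxy differ at all in this assay.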